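This account rests on a few compounds, and the source may have more. Where it says the series, first, only, none or still open, it means among the compounds named here.

Working notes on the series.

Three compounds have been run in a functional assay on KM12 cells (Homo sapiens) for inhibition, read by sulforhodamine B assay, with a stated time of 48 h, tested at 10 uM; a lower number here means less inhibition, a higher number more inhibition at the concentration tested (going by the name of the read-out). Compound 1 `c1ccc2c(-c3cn4ccnc4c(-c4ccc5ncn(C6CCCCC6)c5c4)n3)cccc2c1` gives 11.1%. Compound 2 `c1ccc(Cn2cnc3ccc(-c4nc(-c5cccc6ccccc56)cn5ccnc45)cc32)cc1` differs from compound 1 by benzyl in place of cyclohexyl on an aromatic nitrogen. In this assay compound 2 gives 11%; the step of a number 0.1 percentage points lower from compound 1 to compound 2 (within the scatter) is within the scatter, so the two values cannot be ordered. Compound 3 `c1cn2cc(-c3ccc4c(c3)ncn4C3CCCCC3)nc(-c3ccc4ncn(C5CCCCC5)c4c3)c2n1` gives 30.6% and stands highest of the three, with compound 1 nearest and compound 2 furthest, both beyond the scatter; the difference between the core of compound 3 and the core of compound 1 is not broken down here.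

Compound 4 `c1ccc(Cn2cnc3ccc(-c4nc(-c5ccc6c(c5)ncn6C5CCCCC5)cn5ccnc45)cc32)cc1` is not yet measured. Among the compounds with values here, it differs from compound 3 by benzyl in place of cyclohexyl on an aromatic nitrogen, the same change as the one between compound 1 and compound 2, at a place described in the same words. That earlier step, a number 0.1 percentage points lower from compound 1 to compound 2 (within the scatter), was within the scatter, so the expected step for compound 4 is a number 1.6 percentage points lower from compound 3 to compound 4 (within the scatter), resting on that single precedent. The value expected for compound 4 in this assay is therefore 29%, estimated between 13% and 45%.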

Compound 4, a percentage reported as inhibition, at one concentration (the size of the read-out at that concentration, not a potency): -39.4%
Estimate against measurement, compound 4: 68.4 percentage points above, outside the stated range (below it).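

In this assay, benzyl in place of cyclohexyl on an aromatic nitrogen gives a number 70 percentage points lower from compound 3 to compound 4 (beyond the scatter), and the change does not carry over at one size from one core to the other: the same change on two cores in this assay, a number 0.1 percentage points lower (within the scatter) from compound 1 to compound 2 and a number 70 percentage points lower (beyond the scatter) from compound 3 to compound 4, 69.9 percentage points apart, beyond the scatter of two such steps

In this series, then, the step read on the core of compound 1 is no safe guide to the step on the core of compound 3, and the effect of this change has to be read core by core. Within the data shown here, this does not show which feature of the two cores sets the steps apart or how the change behaves on any third core, since only two pairs are available, and compound 4 at -39.4% is a reading at one concentration, not a potency.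

The compounds shown leave open how other groups on that aromatic nitrogen, such as methyl, a longer chain or a chain ending in an amine, would read on these two cores. They also leave open whether a step of this size appears for such groups or only for benzyl.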